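The source may hold more compounds than are shown below. What is called first, only, known or untested is meant among the compounds shown, and "the series" means these compounds.

Three measured compounds point the way. Compound 1 `CO[C@H]1CC[C@H](NC(=O)c2cc(C)n(Cc3cc(Cl)cc4cc(C(C)C)oc34)n2)CC1` carries a different group on its core and a different amide substituent; in an assay on CHO-K1 cells for displacement of a labelled ligand from prostaglandin E2 receptor EP1 subtype (Homo sapiens), read by scintillation counting, with a stated time of 45 min (on this read-out lower numbers stand for stronger inhibition and higher numbers for weaker inhibition), compound 1 gives 316 nM. Compound 2 `Cc1cc(C(=O)NC(C)(C)C)nn1Cc1cc(Cl)cc2cc(-c3ccccc3)oc12`, with a tert-butyl on the amide nitrogen, gives 10 nM in this assay, the low end of the three numbers, and compound 1 lies well beyond the usual scatter of it. Compound 3 `Cc1cc(C(=O)NCC2CCNCC2)nn1Cc1cc(Cl)cc2cc(-c3ccccc3)oc12` gives 20 nM in this assay, and the move from compound 2 to compound 3, a (piperidin-4-yl)methyl in place of the tert-butyl on the amide nitrogen, shows a 2.0-fold higher number from compound 2 to compound 3 (0.30 log units; within the scatter).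

Compound 4 `Cc1cc(C(=O)NCC(O)C(F)(F)F)nn1Cc1cc(Cl)cc2cc(-c3ccccc3)oc12` is not yet measured. It differs from compound 2 by 3,3,3-trifluoro-2-hydroxypropyl in place of tert-butyl on an amide-type nitrogen. Among the measured compounds shown here, only the step from compound 2 to compound 3 bears on this, since it likewise replaces the tert-butyl with a larger chain bearing a hydrogen-bond donor, and that step stayed within the scatter. For the measured compounds named here, compound 1 differs from compound 2 in more than one place and gives no clean step. With that single comparison, a change of roughly a 2.0-fold higher number from compound 2 to compound 4 (0.30 log units; within the scatter) is expected for compound 4, essentially no step beyond the scatter. The estimate for compound 4 in this assay is 20 nM, with a range from 6 nM to 80 nM.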

Compound 4, half-maximal inhibitory concentration: 25.1 nM
Compound 4: middle estimate off by 1.3-fold (0.10 log units), on the low side; the range from low to high includes it.
By their numbers in this assay, from the lowest: compounds 2, 3 and 4 (each within the scatter of the next, the first and the last beyond it); then compound 1.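

In this assay, a 2.5-fold higher number from compound 2 to compound 4 (0.40 log units; beyond the scatter), so this change on the amide-type nitrogen gives the first step away from the tert-butyl compound that lies beyond the scatter, though only modestly, whereas a 2.0-fold higher number from compound 2 to compound 3 (0.30 log units; within the scatter) did not. The two larger chains cannot be told apart, as a 1.3-fold higher number from compound 3 to compound 4 (0.10 log units; within the scatter): at this position, 3,3,3-trifluoro-2-hydroxypropyl, with its fluorines and hydroxyl and no ring, reads the same within the scatter as the (piperidin-4-yl)methyl chain, with its ring amine. No measurement here explains the step from the tert-butyl compound, so its origin remains unknown.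

The compounds shown leave open how the step divides between the hydroxyl and the three fluorines, a question that a plain 2-hydroxypropyl chain and a 3,3,3-trifluoropropyl chain on the same nitrogen could help to settle. Also open, going by these compounds, is how a chain ending in a carboxylic acid would read here, and whether these amide changes would behave the same with the isopropyl group of compound 1 on the core in place of the phenyl group.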